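The compounds below may be only part of what the source reports. "The series", "measured", "known", "first", "only" and "open" are said of these compounds alone.

Measured in an ADME assay on HEp-2 cells (Homo sapiens) for cytotoxicity (a lower number here means that less compound is tolerated, a higher number that more compound is tolerated), so far:
- Compound 1 `Cc1ccc(NC(=O)C(C)NS(=O)(=O)c2cccc3cccnc23)c(C)c1` gives > 50000 nM, a limit of the assay.
- Compound 2 `CC(C)c1ccccc1NC(=O)[C@@H]1CCCN1S(=O)(=O)c1cccc2cccnc12` gives 29900 nM.

Going by the values given here, compound 2 holds the only actual number here, 29900 nM, so there is no measured number to rank it against. Compound 3 `Cc1ccc(C)c(NC(=O)[C@@H]2CCCN2S(=O)(=O)c2cccc3cccnc23)c1` differs from compound 2 by carrying 2,5-dimethylphenyl in place of 2-isopropylphenyl on an amide-type nitrogen. Among the compounds with values here, with no measured step to draw on, the expected change a 1.1-fold higher number from compound 2 to compound 3 (0.04 log units; within the scatter) is none beyond the scatter. For compound 3 the estimated value is 33000 nM, with an expected range of 15000 nM to 70000 nM.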

Compound 3, half-maximal cytotoxic concentration: 30900 nM
Compound 3: middle estimate off by 1.1-fold (0.03 log units), on the high side, within the range that was stated.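

In this assay, going by these compounds alone, this is the first step that can be read at the amide-type nitrogen. Putting 2,5-dimethylphenyl in place of 2-isopropylphenyl gives a 1.0-fold higher number from compound 2 to compound 3 (0.01 log units; within the scatter), so these two substituted phenyl groups stand level in this read-out. Nothing at hand offers a cause for this step.

The compounds shown leave open whether a phenyl group carrying a carboxylic acid or an amine, or a cyclohexyl ring, would read differently on this nitrogen. With only these two groups compared here, no trend at this place can be stated.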